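A few compounds are considered here, and "the series" means these few. Any claim that something is new, unique, unknown or untested is made for them only; others in the source may bear on it.

Measured in a functional assay on U-87MG ATCC cells for inhibition, with U-87 MG (Homo sapiens) as the target, read by MTT assay, with a stated time of 72 h; on this read-out higher numbers stand for weaker inhibition and lower numbers for stronger inhibition:
- Compound 1 `COc1ccccc1-c1csc2cnc(Nc3ccc(NC(=O)CN)cc3)nc12`: 210 nM
- Compound 2 `CNC(=O)c1ccc(Nc2ncc3scc(-c4ccccc4OC)c3n2)cc1`: 710 nM
- Compound 3 `COc1ccccc1-c1csc2cnc(Nc3ccc(C(=O)NC4CCNCC4)cc3C(F)(F)F)nc12`: 2090 nM

Compound 3 has the highest number of the three, so it is the weakest inhibitor here. Compound 4 `COc1ccccc1-c1csc2cnc(Nc3ccc(C(=O)NC4CCNCC4)cc3F)nc12` carries fluoro in place of trifluoromethyl on an aromatic carbon, ortho to a large group: fluoro in place of trifluoromethyl on an aromatic carbon.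

Within the data shown here, the one measured step, a 3.4-fold higher number from compound 1 to compound 2 (0.53 log units; beyond the scatter), changes a different place, so it bears only indirectly, as a guide to size. Compound 1 and compound 2 carry neither group, and both lie below compound 3 at 2090 nM. They also differ from it elsewhere, so a modest drop in this assay is only a tentative expectation. The estimated change is a 2.3-fold lower number from compound 3 to compound 4 (0.37 log units; beyond the scatter). Compound 4 is expected at 900 nM, within an estimated range of 300 nM to 2700 nM.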

Compound 4, half-maximal inhibitory concentration: 2370 nM
Compound 4: middle estimate off by 2.6-fold (0.42 log units), on the low side; the measured number falls inside the stated range.
By their numbers in this assay, from the lowest: compound 1; then compound 2; then compounds 3 and 4 (each within the scatter of the next).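

In this assay fluoro in place of trifluoromethyl on this aromatic carbon, ortho to a large group, gives a 1.1-fold higher number from compound 3 to compound 4 (0.05 log units; within the scatter) and so leaves the number unchanged within the usual scatter. Going from 4 heavy atoms to 1 at this position therefore does not separate the two compounds on this read-out. Nothing available explains why they read alike.

On these data alone, whether plain hydrogen, chloro, methoxy or an amine at this position would read the same remains open. Also open, as far as these compounds go, is whether fluoro and trifluoromethyl would still match without the (piperidin-4-yl)carbamoyl group.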